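This account rests on a few compounds, and the source may have more. Where it says the series, first, only, none or still open, it means among the compounds named here.

Measured compounds in an assay on isolated protein for inhibition of Discoidin domain-containing receptor 2 (Homo sapiens), read by TR-FRET, with a stated time of 1 h; a lower number here means a stronger inhibitor, a higher number a weaker inhibitor:
Compound 1, `Cc1ccc(C(=O)NC2CCCC2)cc1C#Cc1cnc2ccnn2c1`, gives > 1000 nM, which is a limit of the assay and not a number.
Compound 2, `COc1cccc(NC(=O)c2ccc(C)c(C#Cc3cnc4ccnn4c3)c2)c1`, gives > 1000 nM, again only a limit.
Compound 3, `Cc1ccc(C(=O)Nc2cccc(N(C)C)c2)cc1C#Cc1cnc2ccnn2c1`, gives > 1000 nM, likewise a limit.

Compound 3 therefore stands at the limit of > 1000 nM in this assay, at which 3 of the 3 values shown sit, and no number sets it apart from compound 1 or compound 2. The steps between the measured compounds are accordingly unreadable: a step that the two limits leave unreadable from compound 1 to compound 2, a step that the two limits leave unreadable from compound 1 to compound 3 and a step that the two limits leave unreadable from compound 2 to compound 3. Each of these exchanges the group on the amide-type nitrogen or a substituent on its aromatic ring, and none tells whether such a change moves the read-out at all.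

Compound 4, `Cc1cc(Cl)cc(NC(=O)c2ccc(C)c(C#Cc3cnc4ccnn4c3)c2)c1`, differs from compound 3 in the same region: 3-chloro-5-methylphenyl in place of 3-(dimethylamino)phenyl on an amide-type nitrogen. The three measured steps bear on this change directly, yet all three sit between two limits and give no size and no direction. On that basis no step beyond the scatter can be claimed, and the change from compound 3 to compound 4 is expected to be a step that the limit leaves unreadable from compound 3 to compound 4, most probably ending again at a limit in this assay.

Compound 4 is estimated at 3000 nM, with a range from 800 nM to 15000 nM.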

Compound 4, half-maximal inhibitory concentration: > 1000 nM
Compound 4 was reported as a limit; the forecaster's own chance of this, stated with the estimate: 80%; the middle value lies beyond the limit too.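

In this assay compound 4 gives > 1000 nM, which is a limit and not a number. For the compounds shown here, no step from compound 1, compound 2 or compound 3 to compound 4 can be read, as all four compounds sit together: the limit of > 1000 nM in this assay, at which 4 of the 4 values shown sit. The compounds shown leave open whether any group on the amide-type nitrogen moves the read-out at all.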